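The source may hold more compounds than are shown below. What is called first, only, known or untested is meant among the compounds shown, and "the series" means these compounds.

Series notes. Three members of the series carry numbers in a functional assay on MDA-MB-231 cells (Homo sapiens) for antiproliferative activity, read by MTT assay, with a stated time of 6 days; on this read-out lower numbers stand for stronger inhibition and higher numbers for weaker inhibition. Compound 1 `CC(=O)O[C@@H]1C=CC(=O)O[C@@H]1[C@@H](COC(=O)c1ccc(Cl)cc1)OC(C)=O` gives 1850 nM; compound 2 `COc1ccc(/C=C/C(=O)OC[C@@H](OCc2ccccc2)[C@H]2OC(=O)C=C[C@H]2OCc2ccccc2)cc1` gives 3260 nM; compound 3 `O=C1C=C[C@@H](OC(=O)c2ccccc2)[C@@H]([C@@H](COC(=O)c2ccccc2)OC(=O)c2ccccc2)O1` gives 52300 nM. Compound 2 sits second highest of the three: its number and that of compound 1 lie within the scatter of each other, while compound 3 stands beyond the scatter with the higher number. Compound 4 `CC(=O)OC[C@@H](OCc1ccccc1)[C@H]1OC(=O)C=C[C@H]1OCc1ccccc1` is unmeasured. It differs from compound 2 by methyl in place of 2-(4-methoxyphenyl)ethenyl on a carbonyl carbon. Among the measured compounds shown here, no measured pair isolates this exchange; the only hint is compound 1, which carries acetyl groups and gives 1850 nM. The expected step in this assay is a 1.2-fold higher number from compound 2 to compound 4 (0.09 log units; within the scatter), within the scatter. Compound 4 is accordingly expected to give 4000 nM, with a range from 1200 nM to 13000 nM.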

Compound 4, half-maximal inhibitory concentration: 6420 nM
Estimate against measurement, compound 4: 1.6-fold (0.21 log units) below, and the stated range covers the measured number.
By their numbers in this assay, from the lowest: compounds 1, 2 and 4 (each within the scatter of the next, the first and the last beyond it); then compound 3.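

In this assay there is a 2.0-fold higher number from compound 2 to compound 4 (0.29 log units; within the scatter) when (2-(4-methoxyphenyl)ethenyl)carbonyl gives way to acetyl. Among the compounds shown here, this is the first pair to isolate one exchange at this place, and it shows that methyl can stand in place of 2-(4-methoxyphenyl)ethenyl on this carbonyl carbon with the two numbers remaining within the scatter of each other. No measurement offers an explanation for this result. The compounds shown leave open how a longer chain or an amine on this carbonyl carbon would read out, and whether the exchange behaves alike on other parts of the core.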